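Arginine for Leucine on a Sulfamoyl Adenosine Core

The source may report more compounds than this note shows. Statements on the series, on what has been measured and on what is new or still open speak of the compounds shown alone.

Measured so far:
- compound 1, `CC(C)C[C@H](N)C(=O)NS(=O)(=O)OC[C@H]1O[C@@H](n2cnc3c(N)ncnc32)[C@H](O)[C@@H]1O`: 1100 nM
- compound 2, `N=C(N)NCCC[C@H](N)C(=O)NS(=O)(=O)OC[C@H]1OC[C@@H](n2cnc3c(N)ncnc32)[C@H](O)[C@@H]1O`: 600 nM

Both compounds were tested in a functional assay on PBMC cells (Homo sapiens) for inhibition; a lower number here means a stronger inhibitor, a higher number a weaker inhibitor. Compound 1 gives 1100 nM in this assay, and compound 2 gives 600 nM. Only these two values are known, and the gap between them is within the usual scatter of repeated measurements, so nothing can be said about one being a stronger or weaker inhibitor than the other. Compound 2 carries the same amino acid side chain as the new compound but a different core, so its value only hints at what that side chain does.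

The new compound is compound 3, `N=C(N)NCCC[C@H](N)C(=O)NS(=O)(=O)OC[C@H]1O[C@@H](n2cnc3c(N)ncnc32)[C@H](O)[C@@H]1O`. It keeps the core of compound 1 and changes one place: a group of 6 heavy atoms (3 carbon, 3 nitrogen; no ring) in place of a group of 3 heavy atoms (3 carbon; no ring), on a saturated chain carbon, two bonds along the chain from an amine nitrogen and a carbonyl carbon. Among the compounds with values here, no measured pair shows this exact change on this core, so the size of the step rests on judgement. A small step toward a lower number in this assay is expected, because compound 2 gives 600 nM with the same side chain. The estimated step from compound 1 to compound 3 is a 2.2-fold lower number from compound 1 to compound 3 (0.34 log units; beyond the scatter). Compound 3 is expected to give about 500 nM, with a likely range from 150 nM to 1500 nM.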

Compound 3, half-maximal inhibitory concentration: 1000 nM
The estimate for compound 3 lay 2.0-fold (0.30 log units) below the measured number, and the stated range covers the measured number.
By their numbers in this assay, from the lowest: compounds 2, 3 and 1 (each within the scatter of the next).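

In this assay, the shared core now gives a direct reading of this position: replacing isopropyl with the group of 6 heavy atoms, on the same saturated chain carbon, comes to a 1.1-fold lower number from compound 1 to compound 3 (0.04 log units; within the scatter). Compound 2 could only hint at what this side chain does, as its core is different, whereas compound 1 and compound 3 differ in this one place alone. The entering group brings 3 carbon and 3 nitrogen atoms, along with hydrogen-bond donors and an acceptor that isopropyl lacks, yet this substantial change in the side chain leaves no difference beyond the scatter, and no measurement shown accounts for that.

This single pair cannot show whether other side chains at this position would also stay within the scatter of compound 1 in this assay, or whether the same swap would read alike on the core of compound 2. A carboxylic acid, a simple primary amine on a chain, or a longer chain ending in the same nitrogen-rich group would test how far this flat reading extends.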